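Chain homologation on two related cores: cytotoxicity notes

The source may hold more compounds than are shown below. What is called first, only, known or untested is meant among the compounds shown, and "the series" means these compounds.

Measured so far, in a toxicity assay on L6 cells (Rattus norvegicus) for inhibition, read by microscopy and resazurin assay, with a stated time of 70 h; a higher number here means a weaker inhibitor, a lower number a stronger inhibitor:
compound 1, `CC1(C)CCc2cc(CNCCCc3ccccc3)c(O)cc2O1`, gives 6500 nM
compound 2, `CC1(C)CCc2cc(CNCCCCc3ccccc3)c(O)cc2O1`, gives 15000 nM
compound 3, `CC1(C)C=Cc2cc(CNCCCc3ccccc3)c(O)cc2O1`, gives 28000 nM

Compound 1 and compound 2 differ by one change, (benzyl in place of phenyl on a saturated chain carbon, three bonds along the chain from an amine nitrogen), and the step of a 2.3-fold higher number from compound 1 to compound 2 (0.36 log units; beyond the scatter) is a modest weakening. How the core of compound 1 and the core of compound 3 differ is not broken down here. Compound 3 carries the highest number of the three; against compound 2 the gap is within the scatter, so no order between them is claimed, while against compound 1 it lies beyond the scatter.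

Compound 4, `CC1(C)C=Cc2cc(CNCCCCc3ccccc3)c(O)cc2O1`, has not been measured. It differs from compound 3 by benzyl in place of phenyl on a saturated chain carbon, three bonds along the chain from an amine nitrogen, the same change, in the same place, as that from compound 1 to compound 2. Among the measured compounds shown here, that earlier step, a 2.3-fold higher number from compound 1 to compound 2 (0.36 log units; beyond the scatter), is the only prior example. A similar step is therefore expected for compound 4, namely a 2.0-fold higher number from compound 3 to compound 4 (0.29 log units; within the scatter). Compound 4 is estimated at 55000 nM, with a plausible range from 25000 nM to 120000 nM.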

Compound 4, half-maximal inhibitory concentration: 19000 nM
Beside the measured number, compound 4's estimate is 2.9-fold (0.46 log units) above it, and the stated range ends above it.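

On the core of compound 3, benzyl in place of phenyl gives a 1.5-fold lower number from compound 3 to compound 4 (0.17 log units; within the scatter) in this assay, so no change in the number can be claimed on this core. Set beside the step on the core of compound 1, the same change does not carry over in size from one core to the other: the same change on two cores in this assay, a 2.3-fold higher number (0.36 log units; beyond the scatter) from compound 1 to compound 2 and a 1.5-fold lower number (0.17 log units; within the scatter) from compound 3 to compound 4, 3.4-fold (0.53 log units) apart, beyond the scatter of two such steps. Among the compounds shown here, this rests on one pair per core and shows only that the step on one core is a poor guide to the step on the other; it does not show why the two steps part, and with the step on the core of compound 3 within the scatter, it does not show a reversal of direction.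

Open, on these data alone, is whether a longer chain on either core would continue this divergence or bring the two cores together. Also open, as far as these compounds go, is whether the two cores would part in the same way with an amide in place of the amine.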